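The source may report more compounds than this note shows. Statements on the series, on what has been measured and on what is new or still open speak of the compounds shown alone.

Four compounds built on a shared core are compared here. Compound 1 `CC(Nc1ncnc2ccc(-c3cnn(C4CCNCC4)c3)cc12)c1c(Cl)ccc(F)c1Cl` and compound 2 `CC(Nc1nc(N)nc2ccc(-c3cnn(C4CCNCC4)c3)cc12)c1c(Cl)ccc(F)c1Cl` carry one linkage between the core and the side group, while compound 3 `CC(Oc1nc(N)nc2ccc(-c3cnn(C4CCNCC4)c3)cc12)c1c(Cl)ccc(F)c1Cl` and the as yet unmeasured compound 4 `CC(Oc1ncnc2ccc(-c3cnn(C4CCNCC4)c3)cc12)c1c(Cl)ccc(F)c1Cl` carry another. In a functional assay on MCF7 cells (Homo sapiens) for antiproliferative activity, read by MTT assay, with a stated time of 72 h (on this read-out higher numbers stand for weaker inhibition and lower numbers for stronger inhibition), compound 1 gives 2650 nM, and in the same assay compound 2 gives 2230 nM. The change from compound 2 to compound 1 is hydrogen in place of amino on an aromatic carbon, and it made a 1.2-fold higher number from compound 2 to compound 1 (0.07 log units; within the scatter). Compound 3 gives 1240 nM in this assay; this number sits within the scatter of that of compound 2, while its gap to compound 1 lies beyond it. How the core of compound 3 differs from that of compound 2 is not broken down here.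

Compound 4 differs from compound 3 by hydrogen in place of amino on an aromatic carbon, which is the same change as that from compound 2 to compound 1, the only other place it occurs among these compounds. Because that earlier step a 1.2-fold higher number from compound 2 to compound 1 (0.07 log units; within the scatter) stayed within the scatter, a step of similar size is expected now, and the expected step is a 1.2-fold higher number from compound 3 to compound 4 (0.08 log units; within the scatter). Compound 4 is accordingly estimated at 1500 nM in this assay. Among the measured compounds shown here, its likely range is expected to run from 700 nM to 3500 nM, a width that reflects the single measured instance on which the expectation rests.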

Compound 4, half-maximal inhibitory concentration: 2670 nM
For compound 4 the middle estimate is 1.8-fold (0.25 log units) below the measured one; low and high end bracket the measured number.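

In this assay, hydrogen in place of amino on an aromatic carbon, between two ring nitrogen atoms, gave a 2.2-fold higher number from compound 3 to compound 4 (0.33 log units; beyond the scatter), a modest step. Set beside the earlier instance of the same change, this step does not differ from it by more than repeated measurement would allow: the same change on two cores in this assay, a 1.2-fold higher number (0.07 log units; within the scatter) from compound 2 to compound 1 and a 2.2-fold higher number (0.33 log units; beyond the scatter) from compound 3 to compound 4, 1.8-fold (0.26 log units) apart, within the scatter of two such steps. This shows that, on the evidence of these two pairs, the change can be carried from one core to the other without a demonstrable difference in its size, although only the new step lies beyond the scatter when each is taken alone; it does not show that the amino group matters more on the core of compound 3 than on the core of compound 2, nor that the step would keep its size on any further core, and with only two instances it gives no reason for the difference in their printed sizes.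

The compounds shown leave open whether a methyl group, a methylamino group or a chlorine atom on that same aromatic carbon would give a step of similar size on either core. They also leave open whether the same comparison would hold on any other cell line.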